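The compounds below may be only part of what the source reports. "The series", "measured", "known", "first", "only" and "open" are said of these compounds alone.

Compound 3 `COc1ccc(F)c(-c2ccc(S(=O)(=O)Nc3cc(N4C[C@@H](C)N[C@@H](C)C4)ccc3OC)cc2)c1` gives 0.398 nM in a functional assay for agonist activity at growth hormone secretagogue receptor type 1 (Homo sapiens), read by FLIPR (a higher number here means that more compound is needed for the effect, a lower number that less compound is needed), the lowest of the three numbers recorded. Compound 1 `CCOc1ccc(N2C[C@@H](C)N[C@@H](C)C2)cc1NS(=O)(=O)c1ccc(-c2ccccn2)s1` gives 39.8 nM in this assay, and compound 2 `C[C@@H]1CN(c2ccc(F)c(NS(=O)(=O)c3ccc(-c4ccccn4)s3)c2)C[C@H](C)N1` gives 100 nM; against those, compound 3 stands far apart, beyond the scatter in both cases. Among the compounds with values here, the only single-point step among the measured compounds is a 2.5-fold higher number from compound 1 to compound 2 (0.40 log units; beyond the scatter), a change at the aromatic carbon that carries the alkoxy group, and it does not touch the aryl group that is altered here. Compound 4 `COc1ccc(N2C[C@@H](C)N[C@@H](C)C2)cc1NS(=O)(=O)c1ccc(-c2ccncc2)cc1` differs from compound 3 as follows: pyridin-4-yl in place of 2-fluoro-5-methoxyphenyl on an aromatic carbon. Within the data shown here, no measured pair isolates this change, so the step in this assay is judged from the gap between compound 3 and compound 1, whose aryl group is a different pyridyl on a different ring. A loss is expected, and the step is estimated as a 20-fold higher number from compound 3 to compound 4 (1.30 log units; beyond the scatter). Compound 4 is therefore expected to give about 8 nM in this assay, with a range from 1 nM to 80 nM.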

Compound 4, half-maximal effective concentration: 316 nM
Beside the measured number, compound 4's estimate is 40-fold (1.60 log units) below it, outside the stated range (above it).
By their numbers in this assay, from the lowest: compound 3; then compound 1; then compound 2; then compound 4.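

In this assay, within the data shown here, the aryl group para to a large group proves to matter greatly: pyridin-4-yl in place of 2-fluoro-5-methoxyphenyl gives a 790-fold higher number from compound 3 to compound 4 (2.90 log units; beyond the scatter) and is the first direct reading at this position. Among these compounds, the only earlier step was a 2.5-fold higher number from compound 1 to compound 2 (0.40 log units; beyond the scatter) and lay at another place, so this position responds far more strongly than the earlier compounds could show. Nothing shown here gives a reason for this large step.

Going by these compounds, the change removes the fluoro and methoxy groups and brings in a ring nitrogen all at once, so it remains open which of these carries the loss. An unsubstituted phenyl or a 3-methoxyphenyl group at this place would help separate them.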